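The source may hold more compounds than are shown below. What is called first, only, known or untested is meant among the compounds shown, and "the series" means these compounds.

Measured compounds:
compound 1 `COc1ccc(OC)c(-c2cc(-c3ccc(Cl)cc3)nn2-c2ccccc2)c1` gives 60500 nM;
compound 2 `COc1ccc(OC)c(-c2cc(-c3ccccc3)nn2-c2ccc(S(=O)(=O)NC(C)=O)cc2)c1` gives 12000 nM.

In a functional assay on cells (Cancer cell lines, Homo sapiens) for cytotoxicity, read by sulforhodamine B assay, with a stated time of 48 h (on this read-out higher numbers stand for weaker inhibition of growth and lower numbers for stronger inhibition of growth), compound 2 has the lower of the two numbers, and its gap to compound 1 lies beyond the usual scatter of repeated measurements. Compound 3 `COc1ccc(OC)c(-c2cc(-c3ccc(Cl)cc3)nn2-c2ccc(S(=O)(=O)NC(C)=O)cc2)c1` has not yet been measured in this assay. It differs from compound 2 in one place: chloro in place of hydrogen on an aromatic carbon, on an aromatic carbon of a six-membered aromatic ring of carbon only, para to a large group. Among the compounds with values here, no pair of measured compounds differing only in this way is available, so the size of the step cannot be read from the data. The expectation is a small step from compound 2 to compound 3, toward a lower number or none beyond the scatter: a 1.3-fold lower number from compound 2 to compound 3 (0.12 log units; within the scatter). Compound 3 is accordingly estimated at 9000 nM, with a range from 3000 nM to 30000 nM.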

Compound 3, concentration for 50% growth inhibition: 3610 nM
Beside the measured number, compound 3's estimate is 2.5-fold (0.40 log units) above it; measured number inside the range.
By their numbers in this assay, from the lowest: compound 3; then compound 2; then compound 1.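

In this assay, the change from phenyl to 4-chlorophenyl, with chloro para to a large group, now has a measured size: a 3.3-fold lower number from compound 2 to compound 3 (0.52 log units; beyond the scatter), so this position responds to chloro when the acetylsulfamoyl group is present. Adding the acetylsulfamoyl group, with the 4-chlorophenyl held constant, gives a 17-fold lower number from compound 1 to compound 3 (1.22 log units; beyond the scatter), a large step that shows this second site also affects the read-out. Nothing available here explains either step.

The compounds shown leave open whether chloro would give a similar step in a compound without the acetylsulfamoyl group, and whether fluoro, bromo, methyl or methoxy would match it at the same place. They also leave open how an amine or a carboxylic acid would compare with acetylsulfamoyl at its site.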